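Fluoro for Trifluoromethoxy on the Aryl Ring of Compound 1

The source may hold more compounds than are shown below. What is called first, only, known or untested is meant among the compounds shown, and "the series" means these compounds.

Of the compounds shown here, three sharing one core have been measured in a functional assay on Right cardiac atrium for agonist activity at histamine H2 receptor (Cavia porcellus), with a stated time of 30 min, in the presence of a further agent that is not named here; on this read-out higher numbers stand for an effect only at larger amounts of compound and lower numbers for an effect already at smaller amounts. Compound 1 `Cc1nc(N)sc1CCCN/C(N)=N/C(=O)NC(C)c1ccc(OC(F)(F)F)cc1` gives 724 nM, the highest of the three numbers. Compound 2 `CCC(NC(=O)/N=C(\N)NCCCc1sc(N)nc1C)c1ccccc1` gives 10.7 nM, a far lower number, and compound 3 `Cc1nc(N)sc1CCCN/C(N)=N/C(=O)N[C@H](C)c1ccccc1` gives 7.59 nM, the lowest of the three; both stand well apart from compound 1, beyond the usual scatter, while the two of them lie close to each other. The ring carrying trifluoromethoxy in compound 1 carries no substituent in compound 2 or compound 3.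

Compound 4 `Cc1nc(N)sc1CCCN/C(N)=N/C(=O)NC(C)c1ccc(F)cc1` has not yet been measured. It differs from compound 1 in one place: fluoro in place of trifluoromethoxy on an aromatic carbon. Five heavy atoms leave and one enters, on the same aromatic carbon of the six-membered carbon ring.

Among the compounds with values here, no measured pair shows this exact change, so the expectation rests on the three numbers. Because compound 1 gives 724 nM while the unsubstituted compound 3 gives 7.59 nM, compound 4 is expected to move toward the lower numbers without necessarily reaching them, a step of a 12-fold lower number from compound 1 to compound 4 (1.08 log units; beyond the scatter) in this assay. Compound 4 is estimated at 60 nM, with a range from 15 nM to 300 nM.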

Compound 4, half-maximal effective concentration: 23.4 nM
Estimate against measurement, compound 4: 2.6-fold (0.41 log units) above, within the range that was stated.
By their numbers in this assay, from the lowest: compounds 3 and 2 (each within the scatter of the next); then compound 4; then compound 1.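

Within the data shown here, the step of a 31-fold lower number from compound 1 to compound 4 (1.49 log units; beyond the scatter) in this assay gives the first direct reading at this position, with everything else in the core of compound 1 held unchanged. Among these compounds, compound 2 and compound 3 each differ from compound 1 in more than the ring substituent, so only this pair ties the large change to the group on the aromatic carbon para to a large group, and it shows that this carbon can carry fluoro without the high number seen with trifluoromethoxy. Nothing available explains the size of this step or links it to any property of either group.

The compounds shown leave open how other groups on the same aromatic carbon, such as chloro, methyl or methoxy, would read, and so whether the numbers follow any order across substituents at this position. They also leave fluoro against plain hydrogen unresolved, since compound 3 is written as a single mirror-image form while compound 4 carries no stated configuration, and the two therefore differ in more than one place.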